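A few compounds are considered here, and "the series" means these few. Any claim that something is new, unique, unknown or untested is made for them only; others in the source may bear on it.

Series notes on permeability. Compound 1 `Cn1cncc1CN1CC(N(CCn2cccc2)S(=O)(=O)c2ccccn2)Cc2cc(C#N)ccc21` carries a (1H-pyrrol-1-yl)methyl group on the saturated chain carbon bound to the sulfonamide nitrogen; in an ADME assay on Caco-2 cells (Homo sapiens) for permeability, in the apical to basolateral direction (on this read-out higher numbers stand for higher permeability and lower numbers for lower permeability), compound 1 gives 12.4 10^-6 cm/s. Compound 2 `CCCC(=O)N1CCC(CN(C2Cc3cc(C#N)ccc3N(Cc3cncn3C)C2)S(=O)(=O)c2ccccn2)CC1` gives 0.5 10^-6 cm/s, and compound 3 `Cn1cncc1CN1CC(N(CC2CCN(C(=O)N3CCCC3)CC2)S(=O)(=O)c2ccccn2)Cc2cc(C#N)ccc21` gives 0.6 10^-6 cm/s. Of the three numbers compound 2 is the lowest: its nearest neighbour is compound 3, its furthest is compound 1. The exchange of the (1H-pyrrol-1-yl)methyl group for 1-(propylcarbonyl)piperidin-4-yl is a large step, a 25-fold lower number from compound 1 to compound 2 (1.39 log units; beyond the scatter), whereas the change on the carbonyl carbon, pyrrolidin-1-yl in place of propyl, is a 1.2-fold higher number from compound 2 to compound 3 (0.08 log units; within the scatter).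

Compound 4 `Cn1cncc1CN1CC(N(CC2CCN(C(=O)c3ccccc3)CC2)S(=O)(=O)c2ccccn2)Cc2cc(C#N)ccc21` is the next member and differs from compound 2 as follows: phenyl in place of propyl on a carbonyl carbon. This change sits on the same carbonyl carbon that was varied between compound 2 and compound 3, so that step bears on it directly, and it stayed within the scatter. The large step of a 25-fold lower number from compound 1 to compound 2 (1.39 log units; beyond the scatter) concerns a different position and bears on it only in that compound 2 and compound 3 both lie far under compound 1. For compound 4 no step beyond the scatter is therefore expected in this assay, in either direction; the expected step is a 1.4-fold higher number from compound 2 to compound 4 (0.15 log units; within the scatter). Compound 4 is estimated at 0.7 10^-6 cm/s, with a range from 0.3 10^-6 cm/s to 1.6 10^-6 cm/s.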

Compound 4, apparent permeability: 0.5 10^-6 cm/s
Compound 4: the middle estimate sits 1.4-fold (0.15 log units) above what was measured; the measured number falls inside the stated range.
By their numbers in this assay, from the lowest: compounds 2, 4 and 3 (each within the scatter of the next); then compound 1.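

In this assay, exchanging propyl for phenyl on the carbonyl carbon whose other neighbour is an amide-type nitrogen in a ring gives no change at the digits printed from compound 2 to compound 4 (within the scatter), even though 3 heavy atoms with no ring give way to 6 heavy atoms in a six-membered aromatic ring of carbon only. Among the compounds shown here, the exchange of pyrrolidin-1-yl for phenyl at the same carbon is a 1.2-fold lower number from compound 3 to compound 4 (0.08 log units; within the scatter), so this position now holds three different groups, a chain and two rings, whose numbers all lie within the scatter of one another, where the earlier compounds offered only a single pair. No measurement on hand explains why the read-out stays flat across these three groups.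

Still open, as far as these compounds go, is whether a group of another kind on this carbonyl carbon, such as an aminomethyl group, a carboxylic acid or a longer chain, would also stay within the scatter of these three compounds. Also open is which part of the 1-(propylcarbonyl)piperidin-4-yl group accounts for a 25-fold lower number from compound 1 to compound 2 (1.39 log units; beyond the scatter), a question that a piperidin-4-yl group with no carbonyl on its ring nitrogen would address.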